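This account rests on a few compounds, and the source may have more. Where it says the series, first, only, none or still open, it means among the compounds named here.

Compound 2 `CCCn1c(=O)[nH]c2nc(-c3ccc(S(=O)(=O)N4CCN(Cc5ccc(Br)cc5)CC4)cc3)[nH]c2c1=O` gives 28% in an assay on CHO cells for displacement of a labelled ligand from adenosine receptor A3 (Homo sapiens), read by scintillation counting, with a stated time of 45 min, tested at 1 uM, in the presence of a further agent that is not named here (a lower number here means less inhibition, a higher number more inhibition at the concentration tested (going by the name of the read-out)), the lower of the two numbers at hand. Compound 1 `CCCn1c(=O)[nH]c2nc(-c3ccc(S(=O)(=O)N4CCN(c5cccc(F)c5)CC4)cc3)[nH]c2c1=O` gives 44% in this assay. Going by the values given here, the one step measured so far, a number 16 percentage points lower from compound 1 to compound 2 (beyond the scatter), bears directly on the present change. Compound 3 `CCCn1c(=O)[nH]c2nc(-c3ccc(S(=O)(=O)N4CCN(c5ccccc5Cl)CC4)cc3)[nH]c2c1=O` differs from compound 2 by 2-chlorophenyl in place of 4-bromobenzyl on an amine nitrogen in a ring. Because a number 16 percentage points lower from compound 1 to compound 2 (beyond the scatter) fell when the 4-bromobenzyl replaced the 3-fluorophenyl on the amine nitrogen in a ring, the 2-chlorophenyl in that place is expected to lift the read-out by a number 12 percentage points higher from compound 2 to compound 3 (beyond the scatter). Compound 3 is therefore estimated at 40%, within 25% to 55%.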

Compound 3, a percentage reported as inhibition, at one concentration (the size of the read-out at that concentration, not a potency): 32%
For compound 3 the middle estimate is 8 percentage points above the measured one; the measured number falls inside the stated range.
By their numbers in this assay, from the lowest: compounds 2 and 3 (each within the scatter of the next); then compound 1.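

In this assay the change gives a number 4 percentage points higher from compound 2 to compound 3 (within the scatter), so 2-chlorophenyl and 4-bromobenzyl on the amine nitrogen in a ring cannot be told apart. The direct comparison of the two phenyl groups gives a number 12 percentage points lower from compound 1 to compound 3 (beyond the scatter), so a phenyl ring on this nitrogen does not by itself match compound 1, and the ring's halogen or its place matters. No evidence at hand explains either step. Still open, from the compounds shown here alone, is how an unsubstituted phenyl, or a longer chain ending in an amine or a carboxylic acid, would behave on this nitrogen.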